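Adding a Methyl to the Weakest Core

This account rests on a few compounds, and the source may have more. Where it says the series, first, only, none or still open, it means among the compounds named here.

Compound 3, `c1ccc(-n2cc3cnccc3n2)cc1`, is the smallest member of this set. In a functional assay on K562 cells (Homo sapiens) for inhibition, read by fluorescence, with a stated time of 72 h (on this read-out higher numbers stand for weaker inhibition of growth and lower numbers for stronger inhibition of growth), compound 3 gives > 100000 nM, which is a limit of the assay rather than a number. Compound 4, `Cc1nccc2nn(-c3ccccc3)cc12`, is not yet measured. It differs from compound 3 by methyl in place of hydrogen on an aromatic carbon. Among the measured compounds, compound 1, `Cc1nc(C2CC2)cc2nn(-c3ccccc3)cc12`, gives 25900 nM, and compound 2, `CCCCc1cc2nn(-c3ccccc3)cc2c(C)n1`, gives 8500 nM; both carry the methyl group together with a further group on the shared core, and the step from one to the other, a 3.0-fold lower number from compound 1 to compound 2 (0.48 log units; beyond the scatter), changes the second group, not the methyl. Within the data shown here, no measured step isolates the methyl alone, so its effect on this assay cannot be read directly; the evidence is only that compound 3 sits at the limit of > 100000 nM in this assay, at which 1 of the 3 values shown sits. The step from compound 3 to compound 4 is therefore expected to be small and uncertain, an at least 1.1-fold lower number from compound 3 to compound 4 (0.04 log units; that floor lies within the scatter). Compound 4 is estimated at 90000 nM, within a range from 30000 nM to 300000 nM.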

Compound 4, concentration for 50% growth inhibition: > 100000 nM
Compound 4 gave a limit, no number (the forecaster's own chance of this, stated with the estimate: 55%); middle value at least 1.1-fold (0.04 log units) away from the limit.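

Methyl in place of hydrogen at this position, on the ring carbon next to the ring nitrogen, does not bring the core to a readable number in this assay, and the step between compound 3 and compound 4 cannot be read, as both ends are limits: the limit of > 100000 nM in this assay, at which 2 of the 4 values shown sit.

What the new compound does show is the size of the second group's contribution: hydrogen in place of butyl gives an at least 11-fold higher number from compound 2 to compound 4 (1.07 log units; beyond the scatter), and hydrogen in place of cyclopropyl gives an at least 3.8-fold higher number from compound 1 to compound 4 (0.58 log units; beyond the scatter). Among these four compounds, then, readable values appear only where butyl or cyclopropyl sits on the core along with the methyl.

Whether the methyl itself adds anything remains open, as no pair shown isolates it on a core that gives a readable number. Also open, going by these compounds, is how a longer chain than butyl, or an amine, would behave in that same place.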